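Compounds 3 and 4: inverted stereocentre at the ring carbon

The source may hold more compounds than are shown below. What is called first, only, known or untested is meant among the compounds shown, and "the series" means these compounds.

Measured in an ADME assay on MT4 cells (Homo sapiens) for cytotoxicity, read by MTT assay, with a stated time of 5 days; on this read-out higher numbers stand for lower toxicity in this test and lower numbers for higher toxicity in this test:
compound 1 `Cc1cc(C)cc(S(=O)(=O)c2c(C(=O)N[C@@H]3CCN(Cc4n[nH]c(=O)n4C)C3)[nH]c3ccc(Cl)cc23)c1`: 22400 nM
compound 2 `Cc1cc(C)cc(S(=O)(=O)c2c(C(=O)N[C@@H]3CCN(Cc4ccccc4C#N)C3)[nH]c3ccc(Cl)cc23)c1`: >= 186000 nM (a limit)
compound 3 `Cc1cc(C)cc(S(=O)(=O)c2c(C(=O)N[C@@H]3CCN(S(C)(=O)=O)C3)[nH]c3ccc(Cl)cc23)c1`: 24000 nM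

Compound 3 stands level with compound 1 (a 1.1-fold higher number from compound 1 to compound 3 (0.03 log units; within the scatter)). Compound 2 gives only a limit (>= 186000 nM). Against that limit, the gap to compound 3 is large (an at least 7.7-fold lower number from compound 2 to compound 3 (0.88 log units; beyond the scatter)).

Next comes compound 4 `Cc1cc(C)cc(S(=O)(=O)c2c(C(=O)N[C@H]3CCN(S(C)(=O)=O)C3)[nH]c3ccc(Cl)cc23)c1`. The change is this: the two compounds have the same atoms and bonds and differ only in configuration as drawn: 1 of 1 stereo elements differ; a stereocentre at a saturated ring carbon is drawn R in compound 3 and S in compound 4. Both measured steps to compound 3 replace the group on the ring amine nitrogen, and neither changes configuration, so neither sets a size for this change. In this assay no step beyond the scatter is expected, and no direction is favoured. The expected step is small (no change at the digits printed from compound 3 to compound 4 (within the scatter)). For compound 4 the estimated value is 24000 nM, with an expected range of 10000 nM to 60000 nM.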

Compound 4, half-maximal cytotoxic concentration: 29900 nM
For compound 4 the middle estimate is 1.2-fold (0.10 log units) below the measured one; the measured number falls inside the stated range.
By their numbers in this assay, from the lowest: compounds 1, 3 and 4 (each within the scatter of the next). At a limit, above all of these: compound 2.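

Inverting the stereocentre at the saturated ring carbon, with methylsulfonyl kept on the ring amine nitrogen, gives a 1.2-fold higher number from compound 3 to compound 4 (0.10 log units; within the scatter) in this assay. Going by these compounds alone, the earlier steps all replaced the group on the ring amine nitrogen; this is the first reading of configuration at this carbon, and here the read-out does not separate the two forms.

Going by these compounds, whether the two configurations stay level with another group on that nitrogen, such as 2-cyanobenzyl or acetyl, remains open. Compound 2, the only 2-cyanobenzyl case, gives just a limit, >= 186000 nM.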